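A few compounds are considered here, and "the series" means these few. Any claim that something is new, unique, unknown or untested is made for them only; others in the source may bear on it.

Compound 3 `O=C(NCC1(c2nc(-c3ccccc3)cs2)CCOCC1)c1ccc(Nc2ccccn2)cc1` stands second highest of the three measured values, giving 12000 nM in a physicochemical assay for solubility, read by chemiluminescence, in phosphate buffer, measured as kinetic solubility, at pH 7.4; on this read-out higher numbers stand for higher solubility and lower numbers for lower solubility. Compound 1 `O=C(NCC1(c2nc(-c3ccccc3)cs2)CCOCC1)c1ccc(Nc2nc3ccccc3s2)cc1` gives 4000 nM, and compound 2 `O=C(NCC1(c2nc(-c3ccccc3)cs2)CCOCC1)c1ccc(-n2ccnc2)cc1` gives 193000 nM. Compound 4 `Cn1c(Nc2ccc(C(=O)NCC3(c4nc(-c5ccccc5)cs4)CCOCC3)cc2)nc2ccccc21` has not been measured; it differs from compound 3 by 1-methyl-1H-benzimidazol-2-yl in place of pyridin-2-yl on a nitrogen on an aromatic ring. The step that bears on it is a 3.0-fold higher number from compound 1 to compound 3 (0.48 log units; beyond the scatter), which runs the other way: 1,3-benzothiazol-2-yl gave way to pyridin-2-yl on the same nitrogen. With 1-methyl-1H-benzimidazol-2-yl entering on that nitrogen, a group resembling the 1,3-benzothiazol-2-yl of compound 1, a modest drop back toward compound 1 is expected. Compound 4 is expected to give 5000 nM, in the range 1500 nM to 15000 nM. The estimated step is a 2.4-fold lower number from compound 3 to compound 4 (0.38 log units; beyond the scatter).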

Compound 4, solubility: 10000 nM
Beside the measured number, compound 4's estimate is 2.0-fold (0.30 log units) below it; low and high end bracket the measured number.
By their numbers in this assay, from the lowest: compound 1; then compounds 4 and 3 (each within the scatter of the next); then compound 2.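

On a nitrogen on an aromatic ring in this assay, 1-methyl-1H-benzimidazol-2-yl in place of pyridin-2-yl gives a 1.2-fold lower number from compound 3 to compound 4 (0.08 log units; within the scatter). Thus the larger group does not bring back the low number of compound 1, as the remaining difference shows: a 2.5-fold higher number from compound 1 to compound 4 (0.40 log units; beyond the scatter). Compound 2 stays far apart, with the change to (1-methyl-1H-benzimidazol-2-yl)amino on an aromatic carbon giving a 19-fold lower number from compound 2 to compound 4 (1.29 log units; beyond the scatter).

No measurement shown explains these differences. As far as these compounds go, it remains open how a piperidine or a carboxylic acid on this nitrogen would read out.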